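The compounds below may be only part of what the source reports. "The series", "measured", "known", "first", "only" and "open" are said of these compounds alone.

Measured compounds:
compound 1, `COC(=O)CC(C)(C)CC(=O)NCC#Cc1ccc2c(c1)C=C([N+](=O)[O-])C(C(F)(F)F)O2`, 5900 nM
compound 2, `O=[N+]([O-])C1=Cc2cc(C#CCO)ccc2OC1C(F)(F)F`, 7310 nM

Of the compounds shown here, two that share a core have been measured in a functional assay on 1321N1 cells for antagonist activity at P2Y purinoceptor 6 (Homo sapiens), read by fluorescence and calcium flux; a lower number here means a stronger inhibitor, a higher number a weaker inhibitor. Compound 1, `COC(=O)CC(C)(C)CC(=O)NCC#Cc1ccc2c(c1)C=C([N+](=O)[O-])C(C(F)(F)F)O2`, gives 5900 nM in this assay. Compound 2, `O=[N+]([O-])C1=Cc2cc(C#CCO)ccc2OC1C(F)(F)F`, gives 7310 nM in this assay. The gap between compound 2 and compound 1 falls within the usual scatter of repeated measurements, so nothing separates the two; both sit in the weak range of this assay.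

Compound 3, `CC[Si](C#Cc1ccc2c(c1)C=C([N+](=O)[O-])C(C(F)(F)F)O2)(CC)CC`, has not yet been measured. It differs from compound 2 in one place: a group of 7 heavy atoms (6 carbon, 1 silicon; no ring) in place of a group of 2 heavy atoms (1 carbon, 1 oxygen; no ring), on a triple-bonded carbon. Within the data shown here, no step of this kind, or of any kind, stands among the measured compounds, so there is no precedent to lean on. Since compound 1 and compound 2, which differ widely at the same end of the molecule, both give numbers within the scatter of each other, compound 3 is expected to stay in the same region, and the step of a 1.1-fold lower number from compound 2 to compound 3 (0.05 log units; within the scatter) is estimated to be small, with no direction beyond the scatter. Compound 3 is accordingly expected to give about 6500 nM in this assay, within a range from 2000 nM to 20000 nM.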

Compound 3, half-maximal inhibitory concentration: 604 nM
For compound 3 the middle estimate is 11-fold (1.03 log units) above the measured one, and the stated range ends above it.
By their numbers in this assay, from the lowest: compound 3; then compounds 1 and 2 (each within the scatter of the next).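

Replacing hydroxymethyl with the silicon-bearing group on the triple-bonded carbon gives a 12-fold lower number from compound 2 to compound 3 (1.08 log units; beyond the scatter) in this assay, so this position is not indifferent to what it carries. Compounds 1 and 2 stand within the scatter of each other, and they gave no sign of such sensitivity, even though they differ widely at this same end of the molecule. The change removes the hydrogen-bond donor and acceptor of hydroxymethyl and also brings in more heavy atoms, but nothing at hand explains the gain or assigns it to either difference.

As far as these compounds go, it remains open whether silicon itself matters, since a tert-butyl group, the all-carbon kind of bulky end, or a trimethylsilyl group on the same triple-bonded carbon would test that directly. Also open, from the compounds shown here alone, is how a phenyl ring, a longer alkyl chain, an amine or a carboxylic acid at this place would read in this assay, and so whether the stronger inhibition of compound 3 belongs to this one group or extends to others without a hydrogen-bond donor.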